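Adding hydroxy to compound 2: working notes

A few compounds are considered here, and "the series" means these few. Any claim that something is new, unique, unknown or untested is made for them only; others in the source may bear on it.

Measured in a functional assay on P388 cells (Mus musculus) for antiproliferative activity, read by colorimetric assay and MTT assay; a lower number here means a stronger inhibitor, a higher number a weaker inhibitor
Compound 1 `O=S(=O)(Nc1cccc2cc(O)[nH]c12)c1ccc(Cl)cc1` gives 2.2 ug/mL
Compound 2 `O=[N+]([O-])c1ccc(S(=O)(=O)Nc2cccc3cc[nH]c23)cc1` gives 8.2 ug/mL

In this assay compound 2 has the higher of the two numbers, and compound 1 lies below it by more than the scatter. Compound 3 `O=[N+]([O-])c1ccc(S(=O)(=O)Nc2cccc3cc(O)[nH]c23)cc1` differs from compound 2 by one change hydroxy in place of hydrogen on an aromatic carbon with hydroxy in place of hydrogen on an aromatic carbon. Going by the values given here, no measured step isolates this change. Compound 1 shares the hydroxy and gives 2.2 ug/mL but also differs from compound 3 elsewhere. The expected step is a 2.3-fold lower number from compound 2 to compound 3 (0.37 log units; beyond the scatter) and points to a lower number. For compound 3 the expected value is 3.5 ug/mL (from 1.2 ug/mL to 10 ug/mL) on this estimate.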

Compound 3, half-maximal inhibitory concentration: > 100 ug/mL
Compound 3: no number, only a limit; the forecaster's own chance of this, stated with the estimate: 3%; at least 28-fold (1.45 log units) between middle value and limit.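

In this assay compound 3 gives only a limit, not a number: the limit of > 100 ug/mL in this assay, at which 1 of the 3 values shown sits.

Hydroxy in place of hydrogen on this aromatic carbon, next to the ring nitrogen, gives an at least 12-fold higher number from compound 2 to compound 3 (1.08 log units; beyond the scatter), so this single change with nitro present is large. With hydroxy kept, nitro in place of chloro gives an at least 45-fold higher number from compound 1 to compound 3 (1.65 log units; beyond the scatter), so hydroxy at this position is compatible with a measured value in compound 1 but not in compound 3.

On these data alone, it remains open whether the shift belongs to hydroxy alone or to hydroxy combined with nitro, and how an amine or a methoxy group at this position would read.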